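Benzylidene series: hydroxyl-to-fluorine swap on the pendant ring

The compounds below may be only part of what the source reports. "The series", "measured", "known", "first", "only" and "open" are said of these compounds alone.

Measured so far:
compound 1 `Cc1cccc2c1N(CC(=O)O)C/C(=C\c1cccc(O)c1)C2=O`: 75.6%
compound 2 `Cc1ccc2c(c1)C(=O)/C(=C/c1ccc(Cl)cc1)CN2CC(=O)O`: 20.7%

Within the data shown here, in an assay on HL-60 cells for inhibition of glutathione S-transferase P (Homo sapiens), read by spectrophotometry, tested at 20 uM (a lower number here means less inhibition, a higher number more inhibition at the concentration tested (going by the name of the read-out)), compound 1 gives 75.6% and stands highest of the two numbers in hand; the only neighbour, compound 2, sits a long way lower at 20.7%, a gap well beyond the scatter. Among the measured compounds shown here, no single-point step between measured compounds exists, so no measured step can be used for calibration.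

Compound 3 `Cc1cccc2c1N(CC(=O)O)C/C(=C\c1ccc(F)cc1)C2=O` is the next candidate. It differs from compound 1 in one place only: 4-fluorophenyl in place of 3-hydroxyphenyl on a double-bonded chain carbon bound to a double-bonded ring carbon. The change removes the single hydrogen-bond donor and the single hydrogen-bond acceptor carried by the leaving group, and nothing else on the shared core moves.

Expectation for this assay: a step down from compound 1 of a size beyond the scatter is expected, a number 30.6 percentage points lower from compound 1 to compound 3 (beyond the scatter), since the only other number in the set, that of compound 2, is far lower and also carries a halogen on the pendant ring, though compound 2 is not a single-change neighbour and no step to it is known. Compound 3 is therefore estimated at 45%, with a range from 20% to 70%. The uncertainty is wide because compound 1 gives 75.6% while compound 2 gives 20.7%, and these two known values span most of the scale.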

Compound 3, a percentage reported as inhibition, at one concentration (the size of the read-out at that concentration, not a potency): 22.9%
Compound 3: middle estimate off by 22.1 percentage points, on the high side; low and high end bracket the measured number.
By their numbers in this assay, from the lowest: compounds 2 and 3 (each within the scatter of the next); then compound 1.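

In this assay, among these compounds, the swap of 3-hydroxyphenyl for 4-fluorophenyl on a double-bonded chain carbon bound to a double-bonded ring carbon gives a number 52.7 percentage points lower from compound 1 to compound 3 (beyond the scatter), the first single-place step, and it shows that the number responds strongly to this position while the shared core stays fixed. The step bundles several differences: the heteroatom goes from oxygen to fluorine, the numbering of the substituted ring carbon goes from 3 to 4, and the count falls from 1 hydrogen-bond donor and 1 hydrogen-bond acceptor to 0 of each, so the size of the step cannot be assigned to any one of them. No measured information on the compounds accounts for the step.

The compounds shown leave open whether the higher number of compound 1 depends on the hydroxyl group itself or on where it sits, a question that 4-hydroxyphenyl and 3-fluorophenyl at this position would separate. They also leave open whether another oxygen or nitrogen group, such as 3-methoxyphenyl or 3-aminophenyl, would hold the number of compound 1.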